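A few compounds are considered here, and "the series" means these few. Any claim that something is new, unique, unknown or untested is made for them only; others in the source may bear on it.

Compound 1 `Cc1ccc(S(=O)(=O)N2CC2(CO[C@@H]2O[C@@H]3CO[C@H](c4ccccc4)O[C@@H]3[C@H](OCc3ccccc3)[C@H]2OCc2ccccc2)c2ccccc2)cc1` is one of three sugar-bearing sulfonamides examined in an ADME assay on MRC5 cells (Homo sapiens) for cytotoxicity, read by MTT assay, with a stated time of 48 h; a higher number here means a weaker inhibitor, a lower number a stronger inhibitor. Compound 1 gives 570000 nM there. Compound 2 `CCCCCCCCCCCCNCC(C)(CO[C@@H]1O[C@@H]2CO[C@H](c3ccccc3)O[C@@H]2[C@H](OCc2ccccc2)[C@H]1OCc1ccccc1)NS(=O)(=O)c1ccc(C)cc1` gives 156000 nM, so compound 1 stands with the higher of the two numbers and compound 2 a lower one, beyond the scatter. Compound 3 `Cc1ccc(S(=O)(=O)N2C(CO[C@@H]3O[C@@H]4CO[C@H](c5ccccc5)O[C@@H]4[C@H](OCc4ccccc4)[C@H]3OCc3ccccc3)C2(C)C)cc1` is reported only as a limit of this assay, > 1000000 nM, and the limit of > 1000000 nM in this assay, at which 1 of the 3 values shown sits, records that one value of three sits at that limit. Compound 4 `Cc1ccc(S(=O)(=O)N2CC2(C)CO[C@@H]2O[C@@H]3CO[C@H](c4ccccc4)O[C@@H]3[C@H](OCc3ccccc3)[C@H]2OCc2ccccc2)cc1` is the next compound; it differs from compound 1 by methyl in place of phenyl on a saturated ring carbon. Among the measured compounds shown here, no measured step shows this change. For compound 4 a step of a 1.6-fold higher number from compound 1 to compound 4 (0.20 log units; within the scatter) toward a weaker number is expected. Compound 4 is thus estimated at 900000 nM, within 400000 nM to 2000000 nM.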

Compound 4, half-maximal inhibitory concentration: > 1000000 nM
Compound 4 gave a limit, no number (the forecaster's own chance of this, stated with the estimate: 45%); middle value at least 1.1-fold (0.04 log units) from the limit.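

This position now has its first measured change: in this assay, methyl in place of phenyl on a saturated ring carbon gives an at least 1.7-fold higher number from compound 1 to compound 4 (0.24 log units; that floor lies within the scatter). Compound 4 is a limit and not a number, so this step has only a floor and the full size of the change cannot be read. Compound 3 and compound 4 now rest at the same limit, which narrows what can be compared: the limit of > 1000000 nM in this assay, at which 2 of the 4 values shown sit.

The compounds shown leave open how an ethyl group or an amine on this saturated ring carbon would read. They also leave open whether any replacement for phenyl there gives a number clearly apart from compound 1.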